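Replacing methoxy with thiazolyloxy on a pyrimidine sulfonamide

The compounds below may be only part of what the source reports. "The series", "measured", "known", "first", "only" and "open" are said of these compounds alone.

Compound 1 `COc1cccc(Oc2c(NS(=O)(=O)c3ccc(C(C)(C)C)cc3)ncnc2OCCOc2ccccc2)c1`: 65 nM
Compound 2 `COCCOc1ncnc(NS(=O)(=O)c2ccc(C(C)(C)C)cc2)c1Oc1cccc(OC)c1`: 92 nM
Compound 3 `COc1cccc(Oc2c(NS(=O)(=O)c3ccc(C(C)(C)C)cc3)ncnc2OCCOc2ncccn2)c1`: 1.9 nM

In an assay on cells (Endothelial cell) for binding affinity to Endothelin-1 receptor (Sus scrofa) (a higher number here means a weaker inhibitor, a lower number a stronger inhibitor), compound 2 gives 92 nM, the highest of the three numbers; compound 1 gives 65 nM, within the scatter of compound 2, and compound 3 gives 1.9 nM. Compound 4 `COc1cccc(Oc2c(NS(=O)(=O)c3ccc(C(C)(C)C)cc3)ncnc2OCCOc2nccs2)c1` has not been measured; it differs from compound 2 by 1,3-thiazol-2-yl in place of methyl on an oxygen on a saturated carbon. Within the data shown here, two measured steps bear on this: a 1.4-fold higher number from compound 1 to compound 2 (0.15 log units; within the scatter) and the large step of a 48-fold lower number from compound 2 to compound 3 (1.69 log units; beyond the scatter). Since the pyrimidin-2-yl step brings an aromatic ring with nitrogen onto the same oxygen, a large decrease is expected for compound 4 in this assay, a 15-fold lower number from compound 2 to compound 4 (1.19 log units; beyond the scatter), though no five-membered ring has been measured here. Compound 4 is estimated at 6 nM, with a range from 1.5 nM to 25 nM.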

Compound 4, half-maximal inhibitory concentration: 12 nM
The estimate for compound 4 lay 2.0-fold (0.30 log units) below the measured number; measured number inside the range.
By their numbers in this assay, from the lowest: compound 3; then compound 4; then compounds 1 and 2 (each within the scatter of the next).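

In this assay, 1,3-thiazol-2-yl on this oxygen gives a 7.7-fold lower number from compound 2 to compound 4 (0.88 log units; beyond the scatter) and a 5.4-fold lower number from compound 1 to compound 4 (0.73 log units; beyond the scatter), so a lower number does not depend on pyrimidin-2-yl alone and also occurs with a five-membered aromatic ring. The thiazole does not match the pyrimidine, with a 6.3-fold higher number from compound 3 to compound 4 (0.80 log units; beyond the scatter). Nothing available explains this order among the rings. On these data alone, whether pyridin-2-yl or an amine in the same place would also give a lower number stays open. So does whether the order of these rings holds with another group on the shared core.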